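Swapping bromo for chloro on a weak growth inhibitor

The source may report more compounds than this note shows. Statements on the series, on what has been measured and on what is new or still open speak of the compounds shown alone.

Measured compounds:
compound 1 `COC(=O)[C@@]1(C)CCC=C2[C@@H]1CC[C@@H](C)[C@]2(C)Cc1c(C)[nH]c2c(Br)cccc12`: 31000 nM
compound 2 `COC(=O)[C@@]1(C)CCC=C2[C@@H]1CC[C@@H](C)[C@]2(C)Cc1c(C)[nH]c2c(Cl)cccc12`: 27000 nM
compound 3 `COC(=O)[C@@]1(C)CC[C@@H]2C3=C1CC[C@@H](C)[C@]3(C)Cc1c2[nH]c2c(Br)cccc12`: 31000 nM

Of the compounds shown here, three have been tested in a functional assay on T47D cells (Homo sapiens) for inhibition, read by sulforhodamine B assay, with a stated time of 48 h; a lower number here means a stronger inhibitor of growth, a higher number a weaker inhibitor of growth. Compound 1 `COC(=O)[C@@]1(C)CCC=C2[C@@H]1CC[C@@H](C)[C@]2(C)Cc1c(C)[nH]c2c(Br)cccc12` gives 31000 nM in this assay. Compound 2 `COC(=O)[C@@]1(C)CCC=C2[C@@H]1CC[C@@H](C)[C@]2(C)Cc1c(C)[nH]c2c(Cl)cccc12` gives 27000 nM. The two differ in one place only, (chloro in place of bromo on an aromatic carbon), and that change made a 1.1-fold lower number from compound 1 to compound 2 (0.06 log units; within the scatter). Compound 3 `COC(=O)[C@@]1(C)CC[C@@H]2C3=C1CC[C@@H](C)[C@]3(C)Cc1c2[nH]c2c(Br)cccc12` gives 31000 nM, which stands level with compound 1. The difference between the core of compound 3 and the core of compound 1 is not broken down here.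

Compound 4 `COC(=O)[C@@]1(C)CC[C@@H]2C3=C1CC[C@@H](C)[C@]3(C)Cc1c2[nH]c2c(Cl)cccc12` has not yet been measured. It differs from compound 3 by chloro in place of bromo on an aromatic carbon. For the measured compounds named here, this is the same kind of change as the one from compound 1 to compound 2, but the surroundings differ: in compound 1 the aromatic carbon is part of a fused or bridged system of two rings, in compound 3 part of a fused or bridged system of five rings.

Since the step from compound 1 to compound 2 stayed within the scatter, as shown by a 1.1-fold lower number from compound 1 to compound 2 (0.06 log units; within the scatter), the step from compound 3 to compound 4 is expected to be of about the same small size, a 1.1-fold lower number from compound 3 to compound 4 (0.04 log units; within the scatter), resting on the value of compound 3, 31000 nM. Compound 4 is therefore estimated to give about 28000 nM in this assay, most likely between 14000 nM and 56000 nM.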

Compound 4, concentration for 50% growth inhibition: 21000 nM
For compound 4 the middle estimate is 1.3-fold (0.12 log units) above the measured one, within the range that was stated.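

In this assay, chloro in place of bromo on the aromatic carbon gave a 1.5-fold lower number from compound 3 to compound 4 (0.17 log units; within the scatter), so on this larger fused core the swap again made no change that can be told apart from ordinary assay noise. Set beside the same swap on the other core, the two steps agree: the same change on two cores in this assay, a 1.1-fold lower number (0.06 log units; within the scatter) from compound 1 to compound 2 and a 1.5-fold lower number (0.17 log units; within the scatter) from compound 3 to compound 4, 1.3-fold (0.11 log units) apart, within the scatter of two such steps. For the compounds shown here, this shows that, on these two cores, the swap can be carried across without a detectable change in growth inhibition; it does not show that chloro is better than bromo on either core, and with only two pairs it does not show that the same would hold on a third core or in a different cell line.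

The compounds shown carry only bromo or chloro at this place, so they leave open what a methoxy group, an amine or a carboxylic acid on the same aromatic carbon would do to growth inhibition. They also leave open whether a larger change elsewhere, such as an amide or a carboxylic acid in place of the methyl ester shared by all four compounds, would shift these numbers more than either halogen swap did.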